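Sulfonyl aryl variation on the shared core

This account rests on a few compounds, and the source may have more. Where it says the series, first, only, none or still open, it means among the compounds named here.

Measured so far:
Compound 1, `Cc1ccc2ncc(S(=O)(=O)c3ccc(Cl)cc3)c(N3CCC(C)CC3)c2c1`, gives 79% in an assay on isolated protein for displacement of a labelled ligand from metabotropic glutamate receptor 5 (Homo sapiens), with a stated time of 60 min, tested at 1 uM; on this read-out lower numbers stand for less inhibition and higher numbers for more inhibition at the one concentration tested (going by the name of the read-out).
Compound 2, `COc1ccc2ncc(S(=O)(=O)c3ccc(Cl)cc3)c(N3CCC(C)CC3)c2c1`, gives 91%.
Compound 3, `CC1CCN(c2c(S(=O)(=O)c3ccc(Cl)cc3)cnc3ccc(Cl)cc23)CC1`, gives 92%.

Compound 1 stands lowest of the three numbers. The step of a number 12 percentage points higher from compound 1 to compound 2 (beyond the scatter) and the step of a number 13 percentage points higher from compound 1 to compound 3 (beyond the scatter) both go upward and beyond the scatter, while the step of a number 1 percentage points higher from compound 2 to compound 3 (within the scatter) stays within it, so compound 2 and compound 3 cannot be ordered against each other on these numbers.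

The next compound, compound 4, is `Cc1ccc2ncc(S(=O)(=O)c3ccc(C)c(C)c3)c(N3CCC(C)CC3)c2c1`. Relative to compound 1 the change is 3,4-dimethylphenyl in place of 4-chlorophenyl on a sulfonyl sulfur.

None of the three measured steps bears on this change: each of them alters a group on an aromatic carbon of the shared core and leaves the 4-chlorophenyl on the sulfonyl sulfur untouched. Among the measured compounds shown here, there is therefore no comparable step in this small set from which to read a direction or a size, and the only anchor is the value of compound 1.

On that basis no step beyond the scatter is expected, with the estimated step being a number 5 percentage points lower from compound 1 to compound 4 (within the scatter). For compound 4 the estimate in this assay is 74%, in a range from 52% to 90%.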

Compound 4, a percentage reported as inhibition, at one concentration (the size of the read-out at that concentration, not a potency): 90%
Beside the measured number, compound 4's estimate is 16 percentage points below it, and the stated range covers the measured number.
By their numbers in this assay, from the lowest: compound 1; then compounds 4, 2 and 3 (each within the scatter of the next).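

Among the compounds shown here, the sulfonyl sulfur is a second place where the number moves: in this assay, 3,4-dimethylphenyl in place of 4-chlorophenyl gives a number 11 percentage points higher from compound 1 to compound 4 (beyond the scatter), whereas all the earlier steps altered only a group on an aromatic carbon of the shared core. The chlorine of the 4-chlorophenyl is therefore not needed for a high number on the core of compound 1, since compound 4, whose entering group holds carbon only, reaches 90%. No measurement in hand explains this step.

The step swaps two things at once, removing the chloro group and adding two methyl groups, so the compounds shown cannot assign it to either part, and they do not show whether 3,4-dimethylphenyl gives a similar step on the methoxy or chloro versions of the core. Also open, on these data alone, is how this place responds to a plain phenyl, or to an aryl group carrying an amine or a carboxylic acid, and, with only one concentration tested, how any of these numbers would translate into potency.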